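The source may report more compounds than this note shows. Statements on the series, on what has been measured and on what is new or still open speak of the compounds shown alone.

Measured so far in a functional assay on OVCAR-5 cells (Homo sapiens) for cytotoxicity, read by sulforhodamine B assay, with a stated time of 48 h; a lower number here means that less compound is tolerated, a higher number that more compound is tolerated:
- compound 1, `ClCc1ccc(Cn2cnc3c(Cl)ncnc32)cc1`: 34700 nM
- compound 3, `ClCc1ccccc1Cn1cnc2c(Cl)ncnc21`: 25700 nM
- compound 2, `Nc1nc(Cl)c2ncn(Cc3ccc(CCl)cc3)c2n1`: a limit of the assay only, > 100000 nM

Compound 1 and compound 3 are built from the same atoms joined differently; how the two cores differ is not broken down here. Their two values lie within the usual scatter of each other, so no order is drawn between them.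

Compound 2 is compound 1 carrying one change, (amino in place of hydrogen on an aromatic carbon). In this assay that change gives an at least 2.8-fold higher number from compound 1 to compound 2 (0.45 log units; beyond the scatter), and the size of the step is known only as a lower bound, because compound 2 sits at the limit of > 100000 nM in this assay, at which 1 of the 3 values shown sits.

Compound 4, `Nc1nc(Cl)c2ncn(Cc3ccccc3CCl)c2n1`, is not yet measured. It is compound 3 carrying the same change, (amino in place of hydrogen on an aromatic carbon), at a place that matches word for word the place of the change from compound 1 to compound 2.

For the measured compounds named here, with the move from compound 1 to compound 2 as the only precedent, the expectation for compound 4 in this assay is a step of about a 3.1-fold higher number from compound 3 to compound 4 (0.49 log units; beyond the scatter), resting on an at least 2.8-fold higher number from compound 1 to compound 2 (0.45 log units; beyond the scatter) and on the value of compound 3, 25700 nM. Compound 4 is therefore estimated at 80000 nM, expected to fall between 40000 nM and 160000 nM, with a fair chance that the assay again reports only a limit.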

Compound 4, concentration lethal to 50% of the cells: 79400 nM
Compound 4: the middle estimate sits 1.0-fold (0.00 log units) above what was measured, within the range that was stated.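

In this assay, amino in place of hydrogen on an aromatic carbon gives a 3.1-fold higher number from compound 3 to compound 4 (0.49 log units; beyond the scatter), so the higher number seen on the core of compound 1 also appears on the core of compound 3. Both steps run in the same direction, which shows that the direction of the change carries across these two cores, though their sizes cannot be ranked: the same change on two cores in this assay, an at least 2.8-fold higher number (0.45 log units; beyond the scatter) from compound 1 to compound 2 and a 3.1-fold higher number (0.49 log units; beyond the scatter) from compound 3 to compound 4; the limit leaves it open whether they differ

Compound 2 is recorded only as a limit of the assay, > 100000 nM, and the pattern rests on just two matched pairs, so it shows neither a fixed size for the step nor that the change would behave alike on any further core.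

The compounds shown leave open whether the higher number is particular to amino or would also follow from a different group at the same place, such as a hydroxyl group, a methoxy group or a longer chain ending in an amine. They also leave open how the step behaves when the chloro group on the same ring is replaced, for instance by a methoxy group or a carboxylic acid, and whether it holds in cells other than those of this one assay.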